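Methyl to phenyl on the second chain of compound 2

The source may hold more compounds than are shown below. What is called first, only, known or untested is meant among the compounds shown, and "the series" means these compounds.

The pair of measured compounds differs at one chain only. Compound 1 `CCCOC(=O)C1=C(C)NC(C)=C(C(=O)OCCC)C1c1csc(-c2ccc(Cl)cc2)n1` gives 4800 nM in an assay on isolated protein for antagonist activity at Voltage-dependent L-type calcium channel subunit alpha-1C (Cavia porcellus), with a stated time of 15 min; a lower number here means a stronger inhibitor, a higher number a weaker inhibitor. For the measured compounds named here, compound 2 `CCCOC(=O)C1=C(C)NC(C)=C(C(=O)OC)C1c1csc(-c2ccc(Cl)cc2)n1` gives 5920 nM in this assay; on these two numbers compound 2 has the higher one, with compound 1 its only neighbour, and the two are within the scatter of each other. Going by the values given here, the sole measured step, a 1.2-fold higher number from compound 1 to compound 2 (0.09 log units; within the scatter), shows that shortening a chain at this position left the number essentially unchanged.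

Compound 3 `COC(=O)C1=C(C)NC(C)=C(C(=O)OCCc2ccccc2)C1c1csc(-c2ccc(Cl)cc2)n1` has not been measured. Its change from compound 2 is phenyl in place of methyl on a saturated chain carbon, two bonds along the chain from an oxygen next to a carbonyl group. Among the compounds with values here, no measured step covers this exact change; the one step on the same chain, from compound 1 to compound 2, moved the number only within the scatter. With so little to build on, the expectation is that the phenyl adds at most a modest gain, and compound 3 is expected to give 3500 nM in this assay, between 900 nM and 14000 nM. That expected step, a 1.7-fold lower number from compound 2 to compound 3 (0.23 log units; within the scatter), is small and uncertain in direction.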

Compound 3, half-maximal inhibitory concentration: 10200 nM
Estimate against measurement, compound 3: 2.9-fold (0.46 log units) below; the measured number falls inside the stated range.
By their numbers in this assay, from the lowest: compounds 1, 2 and 3 (each within the scatter of the next, the first and the last beyond it).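

Phenyl in place of methyl on a saturated chain carbon, two bonds along the chain from an oxygen next to a carbonyl group, gives a 1.7-fold higher number from compound 2 to compound 3 (0.24 log units; within the scatter) in this assay and so stays within the usual spread of the measurement. The earlier pair showed only that one propoxy chain could become a methyl ester chain without a change beyond the scatter; this step shows that the propoxy chain kept by compound 2 can become phenethyloxy, taking on one six-membered aromatic ring of carbon only, again without a change beyond the scatter. Nothing available here gives any explanation for this result.

The compounds shown leave open whether an amine or a carboxylic acid on this chain, or a longer chain between the oxygen and the phenyl, would move the number beyond the scatter. They also leave open whether phenethyloxy would behave in the same way if the other chain were propoxy rather than the methyl ester chain of compound 3.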